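Swapping benzyloxy for chloro on a benzoxazolone acid core

The source may report more compounds than this note shows. Statements on the series, on what has been measured and on what is new or still open speak of the compounds shown alone.

Of the compounds shown here, three have been measured in an assay for inhibition of kynurenine 3-monooxygenase (Homo sapiens), read by mass spectrometry, with a stated time of 1 h; on this read-out lower numbers stand for stronger inhibition and higher numbers for weaker inhibition. Compound 1 `O=C(O)CCn1c(=O)oc2cc(OCc3ccccc3)c(Cl)cc21` gives 25.1 nM, the highest number of the three, which on this read-out means the weakest inhibition. Compound 2 `C[C@@H](Oc1cc2oc(=O)n(CCC(=O)O)c2cc1Cl)c1ccc(Cl)cn1` gives 3.16 nM, and compound 3 `C[C@@H](Oc1cc2onc(CCC(=O)O)c2cc1Cl)c1ccccn1` gives 5.01 nM; both of these lie beyond the usual scatter from compound 1, so both inhibit more strongly than compound 1 does.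

Compound 4 `O=C(O)CCn1c(=O)oc2cc(Cl)c(Cl)cc21` has not yet been measured. It differs from compound 1 in one place: chloro in place of benzyloxy on an aromatic carbon. The benzyloxy group is replaced by a single chlorine on the aromatic carbon ortho to the chloro group already present, so compound 4 keeps the core of compound 1 with far fewer atoms on that side.

Because the group that leaves is large and compound 1 at 25.1 nM is already the weakest measured, a loss of inhibition is expected, with a 4.0-fold higher number from compound 1 to compound 4 (0.60 log units; beyond the scatter) likely beyond the scatter. Compound 4 is estimated at 100 nM, within a range from 25 nM to 500 nM.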

Compound 4, half-maximal inhibitory concentration: 6.31 nM
Compound 4: the middle estimate sits 16-fold (1.20 log units) above what was measured; the whole stated range lies above it.
By their numbers in this assay, from the lowest: compounds 2, 3 and 4 (each within the scatter of the next); then compound 1.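

In this assay, replacing the benzyloxy group with a single chloro, on the aromatic carbon ortho to the chloro group already present, gives a 4.0-fold lower number from compound 1 to compound 4 (0.60 log units; beyond the scatter). The large group with its aromatic ring is therefore not required for inhibition at this position, and here the much smaller group goes with stronger inhibition, not weaker. No measurement shown here accounts for the direction of this step.

The compounds shown leave open whether the gain belongs to chloro itself or comes simply from removing the benzyloxy group. A hydrogen, a fluoro, a methyl or a methoxy group on this same carbon would help separate those two readings, and a benzyloxy group shortened to a phenyl would test how much of it can stay.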